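Methyl Groups Replace Trifluoromethoxy on the Aryl Nitrogen

This account rests on a few compounds, and the source may have more. Where it says the series, first, only, none or still open, it means among the compounds named here.

Compound 1, `Cc1ccc(-n2nc(-c3ccc(C(F)(F)F)cc3O)nc2-c2ccccc2O)cc1`: 94.1%
Compound 2, `COc1ccc(-n2nc(-c3ccc(C(F)(F)F)cc3O)nc2-c2ccccc2O)cc1`: 86.6%
Compound 3, `Oc1cc(C(F)(F)F)ccc1-c1nc(-c2ccccc2O)n(-c2ccc(OC(F)(F)F)cc2)n1`: 84.9%

Of the compounds shown here, three with a shared core have been tested in a functional assay on PC-12 cells (Rattus norvegicus) for cytotoxicity, read by MTT assay, with stated times of 2 h and 24 h, tested at 5 uM; on this read-out higher numbers stand for a stronger effect at the one concentration tested and lower numbers for a weaker effect. Compound 3 shows the smallest of the three numbers, but the steps of a number 9.2 percentage points lower from compound 1 to compound 3 (within the scatter) and a number 1.7 percentage points lower from compound 2 to compound 3 (within the scatter) are both within the scatter, so the three stand level. Compound 4, `Cc1cc(C)cc(-n2nc(-c3ccc(C(F)(F)F)cc3O)nc2-c2ccccc2O)c1`, differs from compound 3 by 3,5-dimethylphenyl in place of 4-(trifluoromethoxy)phenyl on an aromatic nitrogen. The step that bears most directly on this exchange is a number 9.2 percentage points lower from compound 1 to compound 3 (within the scatter), which reverses the replacement of methyl by trifluoromethoxy at the same position; a number 7.5 percentage points lower from compound 1 to compound 2 (within the scatter) also concerns this position. Since every measured step stayed within the scatter, no step beyond the scatter is expected here either, and the estimated step of a number 5.1 percentage points higher from compound 3 to compound 4 (within the scatter) is expected to be small. Compound 4 is expected to give 90%, between 79% and 99%.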

Compound 4, a percentage reported as activity, at one concentration (the size of the read-out at that concentration, not a potency): 102%
Estimate against measurement, compound 4: 12 percentage points below; measured number outside the range, above it.
By their numbers in this assay, from the lowest: compounds 3, 2, 1 and 4 (each within the scatter of the next, the first and the last beyond it).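

At the aromatic nitrogen, 3,5-dimethylphenyl produces the first differences beyond the scatter in this assay (a number 17.1 percentage points higher from compound 3 to compound 4 (beyond the scatter); a number 15.4 percentage points higher from compound 2 to compound 4 (beyond the scatter)), whereas every earlier exchange at this position stayed within it. These steps separate 3,5-dimethylphenyl from 4-(trifluoromethoxy)phenyl and 4-methoxyphenyl. It remains within the scatter of 4-methylphenyl (a number 7.9 percentage points higher from compound 1 to compound 4 (within the scatter)), so no advantage over the single methyl group is shown. From the compounds shown here alone, how an amine or a carboxylic acid on this phenyl ring would read remains open. Nothing available accounts for these differences.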